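Methyl on the Phenol Oxygen of Compound 1

The source may hold more compounds than are shown below. What is called first, only, known or untested is meant among the compounds shown, and "the series" means these compounds.

Compound 1 `C=C1[C@@H](OC(C)=O)C[C@@H]2[C@](C)(COC=O)[C@H](OC(C)=O)CC[C@@]2(C)[C@@H]1C[C@@H](Nc1ccc(O)cc1)C1=CCOC1=O`: 29100 nM
Compound 2 `C=C1[C@@H](OC(C)=O)C[C@@H]2[C@](C)(CO[Si](C)(C)C(C)(C)C)[C@H](OC(C)=O)CC[C@@]2(C)[C@@H]1C[C@@H](Nc1ccc(O)cc1)C1=CCOC1=O`: 5090 nM

Within the data shown here, in a functional assay on A549 cells (Homo sapiens) for cytotoxicity, read by sulforhodamine B assay (a lower number here means a stronger inhibitor, a higher number a weaker inhibitor), compound 1 gives 29100 nM, the higher of the two numbers so far, which makes it the weaker inhibitor of the pair. Compound 3 `C=C1[C@@H](OC(C)=O)C[C@@H]2[C@](C)(COC=O)[C@H](OC(C)=O)CC[C@@]2(C)[C@@H]1C[C@@H](Nc1ccc(OC)cc1)C1=CCOC1=O` shares its core and differs in one group: methyl in place of hydrogen on an oxygen on an aromatic ring, so hydroxy becomes methoxy. Among the measured compounds shown here, only one measured step is available, a 5.7-fold lower number from compound 1 to compound 2 (0.76 log units; beyond the scatter). For the measured compounds named here, that change sits elsewhere, on an oxygen on a saturated carbon, so it shows only that a change at another oxygen can shift the number modestly. It says nothing direct about an oxygen on an aromatic ring. A small shift towards a lower number is therefore expected, possibly none beyond the scatter. The expected step is a 1.5-fold lower number from compound 1 to compound 3 (0.16 log units; within the scatter) in this estimate. For compound 3 the estimated value is 20000 nM, with an expected range from 7000 nM to 55000 nM.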

Compound 3, half-maximal inhibitory concentration: 28900 nM
Beside the measured number, compound 3's estimate is 1.4-fold (0.16 log units) below it; the range from low to high includes it.
By their numbers in this assay, from the lowest: compound 2; then compounds 3 and 1 (each within the scatter of the next).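

Going from 4-hydroxyphenyl to 4-methoxyphenyl gives a 1.0-fold lower number from compound 1 to compound 3 (0.00 log units; within the scatter) in this assay. Among these compounds, on this oxygen on an aromatic ring, then, methyl can take the place of hydrogen without a shift that stands out from the scatter, whereas the only earlier step, a 5.7-fold lower number from compound 1 to compound 2 (0.76 log units; beyond the scatter), came from a change at a different oxygen, one on a saturated carbon. Nothing measured here bears on the reason for this result.

The compounds shown leave open whether a longer chain on this oxygen, such as ethyl or benzyl, or an amine or a carboxylic acid in place of the hydroxy group, would move the number. From the compounds shown here alone, it also remains open whether hydroxy to methoxy would read the same on the core of compound 2.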